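Growing a Side Chain on a Shared Core

This account rests on a few compounds, and the source may have more. Where it says the series, first, only, none or still open, it means among the compounds named here.

Three compounds share one core and differ only in a small group on an aromatic carbon. Compound 1 `CN1CCC[C@H]1COc1cccnc1` carries a hydrogen there and gives 0.15 nM in an assay on membranes from brain for displacement of a labelled ligand from Neuronal acetylcholine receptor; alpha4/beta2 (Rattus norvegicus); a lower number here means a stronger inhibitor, a higher number a weaker inhibitor. Compound 2 `Cc1cncc(OC[C@@H]2CCCN2C)c1` carries a methyl and gives 0.48 nM. Compound 3 `CCc1cncc(OC[C@@H]2CCCN2C)c1` carries an ethyl and gives 0.32 nM, which places it second highest of the three numbers: its nearest neighbour is compound 2, and compound 1 is furthest from it.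

Compound 4 `CCCCCCc1cncc(OC[C@@H]2CCCN2C)c1` has not yet been measured. Compared with compound 3 the change is butyl in place of hydrogen on a saturated chain carbon, two bonds along the chain from an aromatic carbon, so the ethyl of compound 3 becomes a hexyl. The measured steps that bear on this are a 3.2-fold higher number from compound 1 to compound 2 (0.51 log units; beyond the scatter), a 2.1-fold higher number from compound 1 to compound 3 (0.33 log units; beyond the scatter) and a 1.5-fold lower number from compound 2 to compound 3 (0.18 log units; within the scatter). Adding a first carbon cost a modest amount, and adding a second carbon changed nothing beyond the scatter. Adding four more carbons is a larger move than anything measured here, so the expectation is uncertain. On balance a modest rise in the number is expected, roughly a 3.1-fold higher number from compound 3 to compound 4 (0.49 log units; beyond the scatter). Compound 4 is therefore estimated at 1 nM, with a range from 0.25 nM to 4 nM.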

Compound 4, inhibition constant: 0.32 nM
The estimate for compound 4 lay 3.1-fold (0.49 log units) above the measured number; measured number inside the range.
By their numbers in this assay, from the lowest: compound 1; then compounds 3, 4 and 2 (each within the scatter of the next).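

In this assay, extending the ethyl of compound 3 to a hexyl gives no change at the digits printed from compound 3 to compound 4 (within the scatter) so butyl in place of hydrogen on this saturated chain carbon, two bonds along the chain from an aromatic carbon, leaves the number where it was. The longer chain also stays close to the methyl, with a 1.5-fold lower number from compound 2 to compound 4 (0.18 log units; within the scatter) and the step from the unsubstituted parent is a 2.1-fold higher number from compound 1 to compound 4 (0.33 log units; beyond the scatter) so hexyl, like methyl and ethyl, carries a modest cost over hydrogen on the aromatic carbon. Across these three chains, that cost does not grow with length, a flat response that the shorter pair alone could not establish over so large an extension, and nothing available explains it.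

Still open, on these data alone, is whether this flat response continues to a longer chain such as a decyl, or survives when the chain ends in an amine or a carboxylic acid. Also open, as far as these compounds go, is whether a different group on this aromatic carbon, such as a fluorine or a methoxy, could match compound 1 at 0.15 nM in the same measurement.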